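Adding a sec-Butyl Group to Compound 3

The source may hold more compounds than are shown below. What is called first, only, known or untested is meant among the compounds shown, and "the series" means these compounds.

Three measured compounds share one core and differ only at a saturated chain carbon bound to an amide-type nitrogen and a carbonyl carbon. Compound 1 `NC(=O)CC[C@H](NC(=O)CN(c1ncnc2c1ncn2C1CCCCO1)C1CC1)C(=O)OCc1ccccc1` carries a 2-carbamoylethyl there, compound 2 `O=C(CN(c1ncnc2c1ncn2C1CCCCO1)C1CC1)N[C@@H](CCC(=O)OCc1ccccc1)C(=O)OCc1ccccc1` a 2-(benzyloxycarbonyl)ethyl, and compound 3 `O=C(CN(c1ncnc2c1ncn2C1CCCCO1)C1CC1)NCC(=O)OCc1ccccc1` a hydrogen. In a functional assay on the whole organism (Tail, strain ICR) with Mus musculus as the target, in the tail flick test, with a stated time of 60 min, at a dose of 25 umol/kg by the oral route (a higher number here means a stronger effect of the compound at the dose given, a lower number a weaker effect), compound 1 gives 39.4%, compound 2 gives 34.7%, and compound 3 gives 40.4%. Compound 3 has the highest of these three numbers, but its gaps to the others are within the scatter: a number 1 percentage points higher from compound 1 to compound 3 (within the scatter) and a number 5.7 percentage points higher from compound 2 to compound 3 (within the scatter). The step between the two larger groups, a number 4.7 percentage points lower from compound 1 to compound 2 (within the scatter), is also within the scatter.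

Compound 4 `CC[C@H](C)[C@H](NC(=O)CN(c1ncnc2c1ncn2C1CCCCO1)C1CC1)C(=O)OCc1ccccc1` is not yet measured. It differs from compound 3 by sec-butyl in place of hydrogen on a saturated chain carbon bound to an amide-type nitrogen and a carbonyl carbon. For the measured compounds named here, the steps that bear on this change are the two that exchanged a group at this same carbon, and both stayed within the scatter. Nothing here points to a move beyond the scatter in this assay. Compound 4 is therefore expected to show a step of a number 2.4 percentage points lower from compound 3 to compound 4 (within the scatter). The estimate for compound 4 is 38%, in a range from 25% to 52%.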

Compound 4, a percentage reported as activity, at one dose (the size of the read-out at that dose, not a potency): 27.4%
Compound 4: the middle estimate sits 10.6 percentage points above what was measured; measured number inside the range.
By their numbers in this assay, from the lowest: compounds 4, 2, 1 and 3 (each within the scatter of the next, the first and the last beyond it).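

For the compounds shown here, at this saturated chain carbon bound to an amide-type nitrogen and a carbonyl carbon, sec-butyl gives the first steps beyond the scatter in this assay (a number 13 percentage points lower from compound 3 to compound 4 (beyond the scatter); a number 12 percentage points lower from compound 1 to compound 4 (beyond the scatter)), so the group carried here can change the effect at the dose given, although both steps are modest and rest on this single compound. The comparison with the larger ester-bearing chain does not show the same thing (a number 7.3 percentage points lower from compound 2 to compound 4 (within the scatter)), so sec-butyl cannot be told apart from 2-(benzyloxycarbonyl)ethyl in this test. No measurement offered here gives a reason for the lower number of compound 4.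

A methyl, an isopropyl or a straight butyl chain at this carbon could show whether the drop goes with the size of the group or with sec-butyl in particular, while an amine or a carboxylic acid on the side chain would test a quite different kind of group. It also remains open what the defined stereocentre of sec-butyl contributes, as only one arrangement of that group appears among these compounds.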